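The source may hold more compounds than are shown below. What is called first, only, known or untested is meant among the compounds shown, and "the series" means these compounds.

Measured so far in a physicochemical assay for pharmacokinetics, read by LC-MS, in phosphate buffer, tested at 1 uM; on this read-out higher numbers stand for a longer-lived compound and lower numbers for a shorter-lived compound:
- Compound 1 `CC#CCNC(=O)c1cccc2c1cc(C)n2-c1nc2c(c(NCc3ccccc3)n1)COCC2`: > 24 h
- Compound 2 `CCC#CC(=O)Nc1cccc2c1cc(C)n2-c1nc2c(c(NCc3ccccc3)n1)CCCC2`: 13.5 h

The value of compound 1 is a limit of the assay, not a number: the limit of > 24 h in this assay, at which 1 of the 2 values shown sits.

Compound 3 `C=CC(=O)Nc1cccc2c1cc(C)n2-c1nc2c(c(NCc3ccccc3)n1)COCC2` has not been measured. It differs from compound 1 on an aromatic carbon, where (vinylcarbonyl)amino enters: a group of 5 heavy atoms (3 carbon, 1 nitrogen, 1 oxygen; no ring) in place of a group of 7 heavy atoms (5 carbon, 1 nitrogen, 1 oxygen; no ring), on an aromatic carbon.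

Going by the values given here, no measured pair shows this change alone, so the expectation rests on two values. Compound 2, at 13.5 h, gives a measured number for a related compound, so a modest shortening is expected, possibly none beyond the scatter. The expected step is an at least 1.2-fold lower number from compound 1 to compound 3 (0.07 log units; that floor lies within the scatter). For compound 3 the estimate is 20 h, with an expected range of 9 h to 45 h.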

Compound 3, half-life: 4.31 h
Compound 3: middle estimate off by 4.6-fold (0.67 log units), on the high side; the whole stated range lies above it.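

Placing (vinylcarbonyl)amino on this aromatic carbon gives, in this assay, an at least 5.5-fold lower number from compound 1 to compound 3 (0.74 log units; beyond the scatter). The group on this carbon can therefore, on its own, move the half-life beyond the scatter while the rest of the molecule stays the same. The full size of the step stays unknown because the starting value is a limit of the assay, not a number: the limit of > 24 h in this assay, at which 1 of the 3 values shown sits.

The whole group changes in this step, so the compounds shown do not tell which part of it matters. Going by these compounds, how a simple amine or a saturated propanoylamino group on this carbon would behave remains open.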